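Ring size on an amide nitrogen and cell tolerance

A few compounds are considered here, and "the series" means these few. Any claim that something is new, unique, unknown or untested is made for them only; others in the source may bear on it.

Compound 1, `CC(C)(C)C(=O)N(CCCCCCN1C[C@H](O)[C@@H](O)[C@H](O)[C@H]1CO)c1ccc(F)cc1F`, in an ADME assay on MDBK cells (Bos taurus) for cytotoxicity, read by MTT assay; a lower number here means that less compound is tolerated, a higher number that more compound is tolerated: > 500000 nM
Compound 2, `CC(C)(C)C(=O)N(CCCCCCN1C[C@H](O)[C@@H](O)[C@H](O)[C@H]1CO)C1CCCC1`, in this assay: > 500000 nM

In this assay compound 1 gives only a limit of the assay, > 500000 nM. Compound 2 likewise returns a limit, > 500000 nM. The step that the two limits leave unreadable from compound 1 to compound 2 is therefore unreadable, and compound 2 stands at that limit with no number behind it. Compound 3, `CC(C)(C)C(=O)N(CCCCCCN1C[C@H](O)[C@@H](O)[C@H](O)[C@H]1CO)C1CCCCCC1`, carries cycloheptyl in place of cyclopentyl on an amide-type nitrogen. Within the data shown here, no measured step bears on this change; the only guide is the limit of > 500000 nM in this assay, at which 2 of the 2 values shown sit. Compound 3 is thus expected to sit at the same limit, a step of a number no higher from compound 2 to compound 3 (the limit leaves the size open) of no readable size. The estimate for compound 3 is 500000 nM, between 200000 nM and 1000000 nM.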

Compound 3, half-maximal cytotoxic concentration: > 500000 nM
Compound 3 was reported as a limit; the forecaster's own chance of this, stated with the estimate: 85%; the middle value lies on the limit itself.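

Among these compounds, no step between compound 1, compound 2 and compound 3 can be read in this assay, since each gives only a limit: the limit of > 500000 nM in this assay, at which 3 of the 3 values shown sit. The compounds shown leave open at what concentration, if any, these cells stop tolerating them, and whether cyclopentyl, cycloheptyl or 2,4-difluorophenyl changes that.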